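The source may report more compounds than this note shows. Statements on the series, on what has been measured and on what is new or still open speak of the compounds shown alone.

Compound 1 `O=S(=O)(Oc1ccccc1)C1CC2OC1C(c1ccc(/C=C/c3cc(O)cc(O)c3)cc1)=C2c1ccc(O)cc1` gives 20100 nM
Compound 2 `Cc1cccc(OS(=O)(=O)C2CC3OC2C(c2ccc(/C=C/c4cc(O)cc(O)c4)cc2)=C3c2ccc(O)cc2)c1` gives 16300 nM

In a functional assay on MCF7 cells (Homo sapiens) for antiproliferative activity, read by MTT assay, with a stated time of 72 h (a lower number here means a stronger inhibitor, a higher number a weaker inhibitor), compound 2 stands level with compound 1 within the scatter, and these two numbers are all that has been measured so far. The change to compound 3 `O=S(=O)(Oc1ccc(O)cc1)C1CC2OC1C(c1ccc(/C=C/c3cc(O)cc(O)c3)cc1)=C2c1ccc(O)cc1` is 4-hydroxyphenyl in place of 3-methylphenyl on an oxygen whose other neighbour is sulfonyl sulfur (4-hydroxyphenyl in place of 3-methylphenyl on an oxygen). Within the data shown here, the one measured step at this group (a 1.2-fold lower number from compound 1 to compound 2 (0.09 log units; within the scatter)) was methyl in place of hydrogen on an aromatic carbon, and it stayed within the scatter. Among the measured compounds shown here, no measured compound carries the 4-hydroxyphenyl group, so the evidence is thin and the margins must be wide. No shift beyond the scatter is expected in this assay and the estimated step is small (a 1.1-fold higher number from compound 2 to compound 3 (0.04 log units; within the scatter)) on this reading. Compound 3 is expected at 18000 nM with an estimated range running from 7000 nM to 45000 nM at its two ends.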

Compound 3, half-maximal inhibitory concentration: 14100 nM
For compound 3 the middle estimate is 1.3-fold (0.11 log units) above the measured one; the measured number falls inside the stated range.
By their numbers in this assay, from the lowest: compounds 3, 2 and 1 (each within the scatter of the next).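

In this assay, the earlier pair had probed this aryl group only with a methyl; now 4-hydroxyphenyl in place of 3-methylphenyl gives a 1.2-fold lower number from compound 2 to compound 3 (0.06 log units; within the scatter), and adding a hydroxy to the unsubstituted phenyl ring gives a 1.4-fold lower number from compound 1 to compound 3 (0.15 log units; within the scatter). A group with a hydrogen-bond donor and acceptor can therefore stand on the oxygen bonded to sulfonyl sulfur while compound 1, compound 2 and compound 3 remain level within the scatter. Nothing available bears on why these numbers stay level.

From the compounds shown here alone, it remains open whether any group on this phenyl ring, such as an amine or a carboxylic acid, or a longer alkyl chain in place of the ring, would move the number beyond the scatter. The shared core is the same in all three compounds, so what its parts contribute cannot be told.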